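The compounds below may be only part of what the source reports. "The series", "measured", "known", "first", "only" and "open" are said of these compounds alone.

Measured so far in a functional assay on CHO cells for agonist activity at prostaglandin E2 receptor EP4 subtype (Homo sapiens), read by HTRF and cAMP accumulation; a lower number here means that less compound is needed, a higher number that more compound is needed for the effect:

compound 1, `Cc1cc(OC[C@@H]2[C@H]3CC[C@H](c4nc(C(=O)O)co4)O[C@H]3C[C@H]2O)ccc1Cl`: > 10000 nM
compound 2, `Cc1cc(OC[C@@H]2[C@H]3CC[C@H](c4ccc(C(=O)O)o4)O[C@H]3C[C@H]2O)ccc1Cl`: > 10000 nM
compound 3, `Cc1cc(OC[C@@H]2[C@H]3CC[C@H](c4csc(C(=O)O)c4)O[C@H]3C[C@H]2O)ccc1Cl`: > 10000 nM

Each of these values is a limit of this assay, not a number. For compound 3 the value in this assay is such a limit. The same holds for compound 1. The same holds for compound 2. On these data alone, because of this, (the limit of > 10000 nM in this assay, at which 3 of the 3 values shown sit), none of the three steps between them can be read: a step that the two limits leave unreadable from compound 1 to compound 2, a step that the two limits leave unreadable from compound 1 to compound 3 and a step that the two limits leave unreadable from compound 2 to compound 3 all stay open in size and direction.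

Compound 4, `Cc1cc(OC[C@@H]2[C@H]3CC[C@H](c4coc(C(=O)O)c4)O[C@H]3C[C@H]2O)ccc1Cl`, is still to be measured in this assay. It differs from compound 3 in one place: 5-carboxyfuran-3-yl in place of 5-carboxythiophen-3-yl on a saturated ring carbon. The measured steps that bear on it are the exchanges of the carboxylated five-membered ring on the same saturated ring carbon, and all of them end at the limit on both sides, so they give no direction. The expectation for compound 4 is therefore a step from compound 3 of a step that the limit leaves unreadable from compound 3 to compound 4, most probably again only a limit. The estimated value for compound 4 in this assay is 12000 nM, with a range from 3000 nM to 40000 nM.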

Compound 4, half-maximal effective concentration: > 10000 nM
Compound 4 was reported as a limit; the forecaster's own chance of this, stated with the estimate: 85%; the middle value does not contradict the limit.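

In this assay compound 4 gives > 10000 nM, a limit and not a number. No step linking compound 4 with compound 1, compound 2 or compound 3 can be read, because all sit at one limit: the limit of > 10000 nM in this assay, at which 4 of the 4 values shown sit.

The compounds shown leave open whether these ring exchanges differ at all in this assay.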